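A few compounds are considered here, and "the series" means these few. Any claim that something is new, unique, unknown or untested is made for them only; others in the source may bear on it.

Compound 2, `CC1=CC[C@H](C(C)C)c2cc(C)c(OC(=O)c3cccc([N+](=O)[O-])c3)cc21`, is the reference point. Among the measured compounds shown here, in a functional assay on PC-3 cells (Homo sapiens) for antiproliferative activity, read by sulforhodamine B assay, with a stated time of 48 h, tested at 50 uM (a higher number here means more inhibition at the concentration tested (going by the name of the read-out), a lower number less inhibition), compound 2 gives 36.9%, the larger of the two numbers recorded, yet its only neighbour, compound 1, `CC1=CC[C@H](C(C)C)c2cc(C)c(OC(=O)c3ccc(Cl)cc3)cc21`, gives 34.1%, and the step of a number 2.8 percentage points higher from compound 1 to compound 2 (within the scatter) lies within the scatter, so the pair cannot be separated. Compound 3, `CC1=CC[C@H](C(C)C)c2cc(C)c(OC(=O)c3ccc(C)cc3)cc21`, differs from compound 2 by 4-methylphenyl in place of 3-nitrophenyl on a carbonyl carbon. For the measured compounds named here, the one measured step bearing on an aryl exchange at this carbonyl carbon stayed within the scatter, so for compound 3 no step beyond the scatter is expected in this assay, a number 2.9 percentage points lower from compound 2 to compound 3 (within the scatter). Compound 3 is therefore estimated at 34%, within 22% to 46%.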

Compound 3, a percentage reported as inhibition, at one concentration (the size of the read-out at that concentration, not a potency): 49.6%
Estimate against measurement, compound 3: 15.6 percentage points below, and the stated range ends below it.
By their numbers in this assay, from the lowest: compounds 1 and 2 (each within the scatter of the next); then compound 3.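

In this assay, an aryl exchange on this carbonyl carbon can move the number beyond the scatter: 4-methylphenyl in place of 3-nitrophenyl gives a number 12.7 percentage points higher from compound 2 to compound 3 (beyond the scatter), and methyl in place of chloro on an aromatic carbon gives a number 15.5 percentage points higher from compound 1 to compound 3 (beyond the scatter). The aryl groups here are therefore not all interchangeable, even though the 3-nitrophenyl and 4-chlorophenyl compounds could not be separated. No measurement at hand accounts for this difference. As far as these compounds go, whether an ethyl group, a methoxy group or an amine in place of that methyl would give a similar number remains open.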